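Swapping the Thiocarbonyl Amine: Pyrrolidine to Morpholine

A few compounds are considered here, and "the series" means these few. Any claim that something is new, unique, unknown or untested is made for them only; others in the source may bear on it.

Three measured compounds share one core and differ in the amine attached to the thiocarbonyl carbon or in the substituent on the bicyclic part. In a functional assay on HeLa cells (Homo sapiens) for antiproliferative activity, read by MTT assay, with a stated time of 72 h (on this read-out lower numbers stand for stronger inhibition and higher numbers for weaker inhibition), compound 1 `CCOC(=O)c1cc(=O)c2cc(CSC(=S)N(C)c3ccccc3)ccc2o1` gives 18100 nM, compound 2 `COc1ccc2oc(CSC(=S)N3CCCCC3)cc(=O)c2c1` gives 11900 nM and compound 3 `CCOC(=O)c1cc(=O)c2cc(CSC(=S)N3CCCC3)ccc2o1` gives 6600 nM. Compound 3 therefore shows the lowest number of the three; its gap to compound 2 stays within the scatter, while its gap to compound 1 lies beyond it.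

Within the data shown here, the one step measured at the amine position is a 2.7-fold lower number from compound 1 to compound 3 (0.44 log units; beyond the scatter), a modest change that lies beyond the scatter. Among the measured compounds shown here, no measured pair shows what happens when one saturated ring amine is exchanged for another.

Compound 4 `CCOC(=O)c1cc(=O)c2cc(CSC(=S)N3CCOCC3)ccc2o1` differs from compound 3 in exactly that way: morpholin-4-yl in place of pyrrolidin-1-yl on a thiocarbonyl carbon. For the measured compounds named here, since the only relevant step, from compound 1 to compound 3, was modest, and since no measured step separates two ring amines, the expectation is for a step in this assay that is small and, if anything, toward a slightly higher number, with no confident direction beyond the scatter; the estimated change is a 1.3-fold higher number from compound 3 to compound 4 (0.11 log units; within the scatter). Compound 4 is accordingly expected to give about 8500 nM, with a likely range from 3500 nM to 21000 nM.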

Compound 4, half-maximal inhibitory concentration: > 25000 nM
Compound 4 ended at the assay's limit; the forecaster's own chance of this, stated with the estimate: 5%; middle value at least 2.9-fold (0.46 log units) away from the limit.
By their numbers in this assay, from the lowest: compounds 3, 2 and 1 (each within the scatter of the next, the first and the last beyond it). At a limit, above all of these: compound 4.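

At the thiocarbonyl carbon, exchanging one saturated ring amine for another is not a neutral change: in this assay, morpholin-4-yl in place of pyrrolidin-1-yl gives an at least 3.7-fold higher number from compound 3 to compound 4 (0.57 log units; beyond the scatter), a larger effect than anything the earlier step at this position could establish. Against methyl(phenyl)amino, the same group gives an at least 1.3-fold higher number from compound 1 to compound 4 (0.14 log units; that floor lies within the scatter), so this floor alone does not separate compound 4 from compound 1. Compound 4 reads > 25000 nM, which is a limit of the assay and not a number, so the full size of both steps cannot be read: the limit of > 25000 nM in this assay, at which 1 of the 4 values shown sits.

The step from pyrrolidin-1-yl to morpholin-4-yl enlarges the ring and adds a ring oxygen together, and the compounds shown do not separate these two differences, since piperidin-1-yl appears only in compound 2, which differs from compound 3 in more than one place. Piperidin-1-yl, thiomorpholin-4-yl or piperazin-1-yl on the core of compound 3 would bear on that question, and whether morpholin-4-yl acts the same way on the core of compound 2 also remains open.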